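Notes on the step from compound 1 to compound 4

The compounds below may be only part of what the source reports. "The series", "measured", "known", "first", "only" and "open" are said of these compounds alone.

Measured so far in an ADME assay on microsomes from liver (Mus musculus) for metabolic stability, read by LC-MS, with a stated time of 30 min, tested at 1 uM (on this read-out higher numbers stand for a more stable compound and lower numbers for a less stable compound), compound 1 `O=C(NCc1ccc(S(=O)(=O)c2ccccc2C(F)(F)F)cc1)c1cc2cnccc2[nH]1` stands highest of the three at 41% and holds a clear lead. Compound 3 `O=C(NCc1ccc(S(=O)(=O)c2cc(F)cc(F)c2)cc1)c1cc2ccncc2o1` gives 12% and compound 2 `O=C(NCc1ccc(S(=O)(=O)N2CCCCC2)cc1)c1ccn2cncc2c1` gives 1% on the same read-out, so both sit lower than compound 1 by more than the scatter. For the measured compounds named here, no two of these three compounds differ in one place only, so no measured step bears directly on the next change.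

Compound 4 `Cc1cccc(S(=O)(=O)c2ccc(CNC(=O)c3cc4cnccc4[nH]3)cc2)c1` differs from compound 1 in one place (3-methylphenyl in place of 2-(trifluoromethyl)phenyl on a sulfonyl sulfur): 3-methylphenyl stands in place of 2-(trifluoromethyl)phenyl on a sulfonyl sulfur. The rest of the structure is shared.

Going by the values given here, with no matched pair to draw on, the expectation in this assay is only a judgement. Compound 1 at 41% is the top of a very small set, so a fall on replacing its group looks more likely than a rise. The expected move is a moderate fall, estimated as a number 16 percentage points lower from compound 1 to compound 4 (beyond the scatter) on this read-out. For compound 4 the estimated value is 25% with an expected range from 8% to 45% as a deliberately wide band.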

Compound 4, percent of the compound remaining: 32%
Beside the measured number, compound 4's estimate is 7 percentage points below it; measured number inside the range.
By their numbers in this assay, from the lowest: compound 2; then compound 3; then compounds 4 and 1 (each within the scatter of the next).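

In this assay, for the compounds shown here, 3-methylphenyl in place of 2-(trifluoromethyl)phenyl on a sulfonyl sulfur gives a number 9 percentage points lower from compound 1 to compound 4 (within the scatter), the first step that can be read at a single place. The exchange takes out all three fluorine atoms and brings the group from 10 heavy atoms to 7, yet the read-out does not separate the two compounds, so in this pair the trifluoromethyl group is not needed to hold the number at this level. Both the substituent and its ring position differ in this one step, so the pair cannot assign any share of the outcome to either, and nothing at hand explains the result.

Compound 2 and compound 3 each differ from compound 1 in more than one place, so what lies behind their values stays open. Also open, from the compounds shown here alone, is whether a plain phenyl, a pyridyl or a morpholine on the sulfonyl sulfur would hold the number in this assay or give a step beyond the scatter, which would show how far this position tolerates change on the shared core.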